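Amide to Urea Change Carried Across Two Cores

This account rests on a few compounds, and the source may have more. Where it says the series, first, only, none or still open, it means among the compounds named here.

Compound 1 `CC(C)C(=O)NCCCc1cccc2oc(CCCCc3ccccc3)cc12` gives 3.7 nM in an assay on NIH3T3 cells for binding affinity to melatonin receptor type 1A (Homo sapiens); a lower number here means a stronger inhibitor, a higher number a weaker inhibitor. Compound 2 `CCNC(=O)NCCCc1cccc2oc(CCCCc3ccccc3)cc12` carries ethylamino in place of isopropyl on a carbonyl carbon and gives 21 nM in this assay, a step of a 5.7-fold higher number from compound 1 to compound 2 (0.75 log units; beyond the scatter). Compound 3 `CC(C)C(=O)N[C@H]1CCN(c2cccc3oc(CCCCc4ccccc4)cc23)C1` rests on another core; the difference between the two cores is not broken down here. In this assay compound 3 gives 105 nM, the highest of the three numbers. Going by the values given here, compound 4 `CCNC(=O)N[C@H]1CCN(c2cccc3oc(CCCCc4ccccc4)cc23)C1` is compound 3 with the same change, (ethylamino in place of isopropyl on a carbonyl carbon), at the same kind of place, so the one earlier example is the only guide. A step of like size, a 5.2-fold higher number from compound 3 to compound 4 (0.72 log units; beyond the scatter), is expected here because a 5.7-fold higher number from compound 1 to compound 2 (0.75 log units; beyond the scatter) followed the same change on the core of compound 1, with a wide margin since a single precedent is thin. On that basis compound 4 is estimated at 550 nM, somewhere between 180 nM and 1700 nM.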

Compound 4, inhibition constant: 39 nM
Compound 4: middle estimate off by 14-fold (1.15 log units), on the high side; the whole stated range lies above it.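

In this assay, ethylamino in place of isopropyl on a carbonyl carbon gave a 2.7-fold lower number from compound 3 to compound 4 (0.43 log units; beyond the scatter), so the change did not carry from the core of compound 1 to the core of compound 3 in either direction or size: the same change on two cores in this assay, a 5.7-fold higher number (0.75 log units; beyond the scatter) from compound 1 to compound 2 and a 2.7-fold lower number (0.43 log units; beyond the scatter) from compound 3 to compound 4, 15-fold (1.18 log units) apart, beyond the scatter of two such steps

For these two pairs, the outcome of the change therefore depends on the core that carries it. Two pairs do not show which feature of the cores is responsible, nor how the change would behave on any further core.

The compounds shown leave open whether other groups on the carbonyl carbon, such as methylamino or cyclopropyl, would also split between the two cores. As far as these compounds go, it also remains open whether a longer chain, such as propylamino, would follow either pair.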